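The source may hold more compounds than are shown below. What is called first, only, known or untested is meant among the compounds shown, and "the series" means these compounds.

Among the measured compounds shown here, compound 2 `CC(C)(C)c1ccc(C(C)(C)NC(=O)c2ccc([N+](=O)[O-])o2)cc1` is one of two compounds so far tested in an ADME assay on Vero cells (Chlorocebus sabaeus) for cytotoxicity, read by MTT assay, with a stated time of 48 h; a lower number here means that less compound is tolerated, a higher number that more compound is tolerated. In this assay compound 2 reaches only the limit, > 150000 nM. Compound 1 `O=C(Nc1ccc2ccccc2c1)c1ccc([N+](=O)[O-])o1` likewise gives only the limit, > 150000 nM, in this assay. For the measured compounds named here, compound 2 thus stands where every value so far sits, as the limit of > 150000 nM in this assay, at which 2 of the 2 values shown sit, shows, with no number to set it apart. Compound 3 `CC(C)(NC(=O)c1ccc([N+](=O)[O-])o1)c1ccc(-c2ccc(Cl)cc2)cc1` differs from compound 2 by 4-chlorophenyl in place of tert-butyl on an aromatic carbon, with 4-chlorophenyl in place of tert-butyl on an aromatic carbon. Going by the values given here, no step between measured compounds exists to guide the size of this change. Among the compounds with values here, because the two values so far both sit at the limit of > 150000 nM in this assay, at which 2 of the 2 values shown sit, the step of a number no higher from compound 2 to compound 3 (the limit leaves the size open) is expected to stay within the scatter. Compound 3 is accordingly expected to give 150000 nM in this assay, within a range of 40000 nM to 300000 nM, with a fair chance that only a limit is again reported.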

Compound 3, half-maximal cytotoxic concentration: > 140000 nM
Compound 3 was reported as a limit; the forecaster's own chance of this, stated with the estimate: 65%; the middle value is on the limit's open side.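

Compound 2 and compound 3 are both reported only as limits in this assay, and the size of the step between compound 2 and compound 3 cannot be read. The compounds shown leave open at what concentration any of them becomes cytotoxic, and whether 4-chlorophenyl in place of tert-butyl alters that concentration.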